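A few compounds are considered here, and "the series" means these few. Any claim that something is new, unique, unknown or untested is made for them only; others in the source may bear on it.

Measured in a functional assay on HepG2 cells (Homo sapiens) for cytotoxicity, read by MTT assay, with a stated time of 72 h; a lower number here means a stronger inhibitor, a higher number a weaker inhibitor:
Compound 1 `Nc1ccccc1NC(=O)c1ccc(NC(=S)NCc2cccc(F)c2)cc1`: 2900 nM
Compound 2 `Nc1ccccc1NC(=O)c1ccc(CNC(=O)c2cc3cccnc3[nH]2)cc1`: 6100 nM
Compound 3 `Nc1ccccc1NC(=O)c1ccc(NC(=O)NCc2cccnc2)cc1`: 5100 nM

Compound 3, at 5100 nM, holds the second highest of the three numbers. It nevertheless lies within the usual scatter of both compound 2 and compound 1, so these data do not separate it from either one.

Compound 4 `Nc1ccccc1NC(=O)c1ccc(NC(=O)NCc2ccc(Cl)nc2)cc1` differs from compound 3 in one place: pyridin-3-yl becomes 6-chloropyridin-3-yl. This puts chloro in place of hydrogen on an aromatic carbon, next to the ring nitrogen: chloro in place of hydrogen on an aromatic carbon.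

Among the measured compounds shown here, no two measured compounds differ in only one place, so nothing here shows directly what such a change does in this assay. For the measured compounds named here, the only guide is the general spread of the numbers, which run from compound 1 at 2900 nM to compound 2 at 6100 nM, even though these compounds differ in several places. A single added atom is therefore expected to shift the number little. The expected change is slight, towards a lower number, and not beyond the scatter: a 1.3-fold lower number from compound 3 to compound 4 (0.11 log units; within the scatter). For compound 4 the estimated value is 4000 nM, with an expected range of 1600 nM to 10000 nM.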

Compound 4, half-maximal inhibitory concentration: 2400 nM
The estimate for compound 4 lay 1.7-fold (0.22 log units) above the measured number; the measured number falls inside the stated range.
By their numbers in this assay, from the lowest: compounds 4, 1, 3 and 2 (each within the scatter of the next, the first and the last beyond it).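

Among the compounds shown here, compound 3 and compound 4 are the first pair here to differ in only one place, so they give the first direct reading of a single change in this assay. Replacing pyridin-3-yl with 6-chloropyridin-3-yl gives a 2.1-fold lower number from compound 3 to compound 4 (0.33 log units; beyond the scatter), which shows that this aromatic carbon next to the ring nitrogen is not a silent spot: one chlorine atom in place of hydrogen is enough to move the number beyond the usual scatter, although the step is modest. Nothing measured here explains why the number moves.

A single substituent at a single place cannot show whether fluoro, methyl, methoxy or an amine on the same carbon would move the number as far, less far or the other way. On these data alone, it also remains open whether chloro would give a similar step on another carbon of this ring, or when added to compounds with a different linker, such as the thiourea of compound 1 or the amide of compound 2.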